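Working notes on an N-substituted chromenone series

The source may hold more compounds than are shown below. What is called first, only, known or untested is meant among the compounds shown, and "the series" means these compounds.

Measured so far:
compound 1 `C=CCNC(=O)n1c(-c2ccc(OC)cc2)cc(=O)c2c(OC)cc(OC)cc21` — 74000 nM
compound 2 `COc1ccc(-c2c(I)c(=O)c3c(OC)cc(OC)cc3n2S(=O)(=O)c2ccc(OC)cc2)cc1` — > 34400 nM
compound 3 `COC(=O)c1cc(=O)c2cc(N)ccc2[nH]1` — > 67200 nM

Among the compounds with values here, compound 1 gives the only actual number in an ADME assay on BJ cells (Homo sapiens) for antiproliferative activity, with a stated time of 72 h; on this read-out lower numbers stand for an effect already at smaller amounts and higher numbers for an effect only at larger amounts of compound. Compound 2 stands at a limit of the assay, > 34400 nM, which is not a number. Compound 3 likewise stands at a limit, > 67200 nM. Both limits are noted as such, the limit of > 34400 nM in this assay, at which 1 of the 3 values shown sits, and (the limit of > 67200 nM in this assay, at which 1 of the 3 values shown sits), so compound 1 cannot be ordered against either of them: all three values sit in the same weak region, and nothing among them is beyond the scatter of any other.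

The next compound, compound 4 `COc1ccc(-c2cc(=O)c3c(OC)cc(OC)cc3n2S(=O)(=O)c2ccc(Cl)cc2)cc1`, has not yet been measured in this assay. It differs from compound 1 in one place: (4-chlorophenyl)sulfonyl in place of allylcarbamoyl on an aromatic nitrogen. Within the data shown here, no step between two measured compounds exists to rest on, so the size of the step from compound 1 to compound 4 is taken from the crowding of all three values at the weak end. The expected step, a 1.2-fold lower number from compound 1 to compound 4 (0.09 log units; within the scatter), is therefore none beyond the scatter, in either direction. For compound 4 the expected value is 60000 nM, with a range from 15000 nM to 150000 nM, and a fair chance that the assay reports only a limit.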

Compound 4, half-maximal effective concentration: > 34400 nM
Compound 4 ended at the assay's limit; the forecaster's own chance of this, stated with the estimate: 45%; the middle value is on the limit's open side.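

In this assay, within the data shown here, compound 4 gives > 34400 nM, a limit of the assay and not a number, so no step from compound 1 to compound 4 can be read. The compounds shown leave open whether (4-chlorophenyl)sulfonyl in place of allylcarbamoyl on the aromatic nitrogen shifts the value in either direction, or at all.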